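Iodo to Fluoro: an Expected Gain in Cytotoxic Potency

The source may hold more compounds than are shown below. What is called first, only, known or untested is meant among the compounds shown, and "the series" means these compounds.

Compound 1 `C/C(=N/NC(=S)Nc1cccc(I)c1)c1ccccn1` gives 61 nM in a functional assay on T98G cells (Homo sapiens) for cytotoxicity, read by MTT assay, with a stated time of 48 h; a higher number here means a weaker inhibitor, a lower number a stronger inhibitor. Compound 2 `CC(=NNC(=S)Nc1ccc(I)cc1)c1ccccn1` gives 64 nM. Compound 3 `CC(=NNC(=S)Nc1ccc(F)cc1)c1ccccn1` gives 17 nM.

Compound 1 and compound 2 are built from the same atoms joined differently; the difference between the two cores is not broken down here, and their two numbers lie within the usual scatter of each other. Between compound 2 and compound 3 one change is made, (fluoro in place of iodo on an aromatic carbon), and it produced a 3.8-fold lower number from compound 2 to compound 3 (0.58 log units; beyond the scatter).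

Compound 4 `C/C(=N/NC(=S)Nc1cccc(F)c1)c1ccccn1` is not yet measured. It differs from compound 1 by fluoro in place of iodo on an aromatic carbon. This is the same kind of change as that from compound 2 to compound 3, not the same: there the fluoro stands para to a large group, here it stands meta to a large group.

For compound 4 the expected step is a 3.1-fold lower number from compound 1 to compound 4 (0.48 log units; beyond the scatter), because the same kind of change gave a 3.8-fold lower number from compound 2 to compound 3 (0.58 log units; beyond the scatter) and compound 1 starts from 61 nM. Compound 4 is therefore estimated at about 20 nM, most likely between 8 nM and 50 nM.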

Compound 4, half-maximal inhibitory concentration: 12 nM
For compound 4 the middle estimate is 1.7-fold (0.22 log units) above the measured one, and the stated range covers the measured number.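

Putting fluoro in place of iodo on the core of compound 1 gave a 5.1-fold lower number from compound 1 to compound 4 (0.71 log units; beyond the scatter) in this assay, so the number falls on this core as it did on the core of compound 2. Set side by side, the two steps run the same way and do not differ by more than the scatter: the same change on two cores in this assay, a 3.8-fold lower number (0.58 log units; beyond the scatter) from compound 2 to compound 3 and a 5.1-fold lower number (0.71 log units; beyond the scatter) from compound 1 to compound 4, 1.4-fold (0.13 log units) apart, within the scatter of two such steps. This suggests that the gain carries between these two closely related cores, with the halogen at a different place on the ring in each pair, but two pairs in one cell assay cannot show that it would hold on a more different core, and they do not explain why the number falls.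

The compounds shown leave open how chloro, bromo or methoxy would compare with iodo and fluoro at these places on the ring. They also leave open whether the step would persist if a longer chain replaced the methyl group of the shared core.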